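This account rests on a few compounds, and the source may have more. Where it says the series, first, only, none or still open, it means among the compounds named here.

Three compounds share one core and differ only in the ring system carried on a saturated chain carbon, two bonds along the chain from an amine nitrogen in a ring. Compound 1 `c1ccc2c(c1)CC2CCCN1CCN(c2cccc3c2OCCO3)CC1` carries a four-membered non-aromatic ring fused to an aromatic ring; in an assay on isolated protein for binding affinity to 5-hydroxytryptamine receptor 1B (Rattus norvegicus) (a higher number here means a weaker inhibitor, a lower number a stronger inhibitor), compound 1 gives 646 nM. Compound 2 `C1=C(CCN2CCN(c3cccc4c3OCCO4)CC2)c2ccccc2C1` carries instead a five-membered non-aromatic ring fused to an aromatic ring, with one double bond outside aromatic rings, and in this assay compound 2 gives 251 nM. Compound 3 `C1=C(CCN2CCN(c3cccc4c3OCCO4)CC2)c2ccccc2CC1` carries a six-membered non-aromatic ring in that place, and in this assay compound 3 gives 229 nM. Among these three numbers compound 2 stands second highest: its gap to compound 3 lies within the scatter, while the step of a 2.6-fold lower number from compound 1 to compound 2 (0.41 log units; beyond the scatter) lies beyond it. Compound 4 `C1=C(CCN2CCN(c3cccc4c3OCCO4)CC2)Cc2ccccc21` has the same atoms as compound 2, joined differently: a group of 9 heavy atoms (9 carbon; one five-membered non-aromatic ring of carbon only, one six-membered aromatic ring of carbon only) in place of a group of 9 heavy atoms (9 carbon; one five-membered non-aromatic ring of carbon only, one six-membered aromatic ring of carbon only), on a saturated chain carbon, two bonds along the chain from an amine nitrogen in a ring. Within the data shown here, no measured step rearranges the ring system while keeping its size, so the step from compound 1 to compound 2 bears only loosely here, and the closeness of compound 2 and compound 3 suggests that this region tolerates change. Compound 4 is therefore expected to give 260 nM, between 110 nM and 620 nM. The step of a 1.0-fold higher number from compound 2 to compound 4 (0.02 log units; within the scatter) that this estimate means is expected to stay within the scatter.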

Compound 4, inhibition constant: 933 nM
Beside the measured number, compound 4's estimate is 3.6-fold (0.55 log units) below it; the whole stated range lies below it.
By their numbers in this assay, from the lowest: compounds 3 and 2 (each within the scatter of the next); then compounds 1 and 4 (each within the scatter of the next).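

Compound 2 and compound 4 have the same atoms, and their groups match in every count, including ring sizes and the double bond outside aromatic rings, yet this assay records a 3.7-fold higher number from compound 2 to compound 4 (0.57 log units; beyond the scatter). The closeness of compound 2 and compound 3 therefore does not mean that this position accepts any change: how the atoms of the group are joined matters, even when ring size and atom count stay the same. With a 1.4-fold higher number from compound 1 to compound 4 (0.16 log units; within the scatter) lying within the scatter, a five-membered non-aromatic ring does not by itself give a lower number than the four-membered one, as only the arrangement in compound 2 does so, and no measurement here explains why the arrangement has this effect.

Going by these compounds, it remains open whether rearranging the atoms of the six-membered ring group in compound 3 would raise the number in the same way. It is also unknown how a longer chain carrying the group of compound 2 or compound 4, or a plain phenyl group at this position, would compare.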